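Replacing 4-methylthiophen-2-yl with 4-fluoropyridin-3-yl in compound 4

The source may report more compounds than this note shows. Statements on the series, on what has been measured and on what is new or still open speak of the compounds shown alone.

Compound 1 `Nc1ccc(S(=O)(=O)N2CCN(c3ncc(C(O)(C(F)(F)F)C(F)(F)F)cc3Br)CC2)cn1`: < 14 mL.min-1.g-1 (a limit of the assay, not a number)
Compound 2 `CCn1cc(-c2cc(C(O)(C(F)(F)F)C(F)(F)F)cnc2N2CCN(S(=O)(=O)c3ccc(N)nc3)CC2)cn1`: 20 mL.min-1.g-1
Compound 3 `Cc1csc(-c2cc(C(O)(C(F)(F)F)C(F)(F)F)cnc2N2CCN(S(=O)(=O)c3ccc(N)nc3)CC2)c1`: 29 mL.min-1.g-1

These values come from an ADME assay (liver) for metabolic stability, with Liver microsome (Homo sapiens) as the target, using microsomes and NADPH, with a stated time of 30 min, tested at 1 uM; on this read-out higher numbers stand for fast clearance and lower numbers for slow clearance. Compound 3 gives 29 mL.min-1.g-1, which lies within the scatter of compound 2. The measured steps show this as a 1.5-fold higher number from compound 2 to compound 3 (0.16 log units; within the scatter). Compared with the bromo compound, the picture is an at least 2.0-fold higher number from compound 1 to compound 3 (0.31 log units; beyond the scatter), and also an at least 1.4-fold higher number from compound 1 to compound 2 (0.15 log units; that floor lies within the scatter).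

Compound 4 `Nc1ccc(S(=O)(=O)N2CCN(c3ncc(C(O)(C(F)(F)F)C(F)(F)F)cc3-c3cnccc3F)CC2)cn1` carries 4-fluoropyridin-3-yl in place of 4-methylthiophen-2-yl on an aromatic carbon. For the measured compounds named here, no measured compound carries this group, so the estimate leans on the nearest comparison. That comparison is the exchange of one aromatic ring for another, a 1.5-fold higher number from compound 2 to compound 3 (0.16 log units; within the scatter), and it stayed within the scatter. Replacing bromo with 4-methylthiophen-2-yl gave an at least 2.0-fold higher number from compound 1 to compound 3 (0.31 log units; beyond the scatter), so removing that group may lower the number slightly. The expected change is a 1.6-fold lower number from compound 3 to compound 4 (0.21 log units; within the scatter), with no clear step beyond the scatter anticipated. The estimate for compound 4 is 18 mL.min-1.g-1, with an expected range of 10 mL.min-1.g-1 to 36 mL.min-1.g-1.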

Compound 4, intrinsic clearance in microsomes: 17 mL.min-1.g-1
Compound 4: middle estimate off by 1.1-fold (0.02 log units), on the high side; low and high end bracket the measured number.
By their numbers in this assay, from the lowest: compounds 4, 2 and 3 (each within the scatter of the next). At a limit, below all of these: compound 1.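

In this assay, the change at this position, on an aromatic carbon ortho to a large group, from a five-membered to a six-membered aromatic ring gives a 1.7-fold lower number from compound 3 to compound 4 (0.23 log units; within the scatter). Set against the 1-ethyl-1H-pyrazol-4-yl group, it gives a 1.2-fold lower number from compound 2 to compound 4 (0.07 log units; within the scatter), so all three aromatic rings shown read alike here, each within the scatter of the others. Against bromo, whose compound sits at a limit of the assay and has no exact number, only a floor can be read, an at least 1.2-fold higher number from compound 1 to compound 4 (0.08 log units; that floor lies within the scatter), which leaves that comparison unsettled: the limit of < 14 mL.min-1.g-1 in this assay, at which 1 of the 4 values shown sits.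

Still open, as far as these compounds go, is whether an amine or a short alkyl chain at this position would move the number beyond the scatter of these rings. Also open, from the compounds shown here alone, is whether a plain pyridin-3-yl ring, without the fluorine, would read like compound 4.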